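The source may report more compounds than this note shows. Statements on the series, on what has been measured and on what is new or still open speak of the compounds shown alone.

Compound 1 `COc1ccc2nc(NC(=O)CCCCC(=O)NO)sc2c1`: 9.07 ug/mL
Compound 2 `O=C(CCCCCCC(=O)Nc1nc2ccccc2s1)NO`: 4.01 ug/mL
Compound 3 `Cc1ccc2nc(NC(=O)CCCCC(=O)NO)sc2c1`: 4.69 ug/mL

In a functional assay on SW-620 cells (Homo sapiens) for cytotoxicity (on this read-out higher numbers stand for weaker inhibition and lower numbers for stronger inhibition), compound 2 at 4.01 ug/mL cannot be told apart from compound 3 at 4.69 ug/mL, since the two lie within the usual scatter. Compound 2 does read lower than compound 1, beyond the scatter. Compound 4 `O=C(CCCCCCC(=O)Nc1nc2ccc([N+](=O)[O-])cc2s1)NO` is compound 2 with nitro in place of hydrogen on an aromatic carbon. Going by the values given here, no measured step adds nitro. The nearest guide is a 1.9-fold lower number from compound 1 to compound 3 (0.29 log units; within the scatter), a different swap on an aromatic carbon. With so little evidence, no shift beyond the scatter is expected in this assay. The expected step is a 1.1-fold lower number from compound 2 to compound 4 (0.02 log units; within the scatter). Compound 4 is expected to give about 3.8 ug/mL, with an estimated range of 1.4 ug/mL to 10 ug/mL.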

Compound 4, half-maximal inhibitory concentration: 0.29 ug/mL
Compound 4: the middle estimate sits 13-fold (1.12 log units) above what was measured; measured number below the stated range.
By their numbers in this assay, from the lowest: compound 4; then compounds 2, 3 and 1 (each within the scatter of the next, the first and the last beyond it).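

Nitro in place of hydrogen gives a 14-fold lower number from compound 2 to compound 4 (1.14 log units; beyond the scatter) in this assay at this aromatic carbon, so a single change on the six-membered ring can move the read-out far beyond the scatter. The swap of methoxy to methyl, on the shorter chain, gave only a 1.9-fold lower number from compound 1 to compound 3 (0.29 log units; within the scatter) and did not show this. No measurement shown explains the size of the nitro step.

From the compounds shown here alone, whether this belongs to nitro alone stays open, and an amine or a chlorine atom on the same carbon would test that. Going by these compounds, whether nitro does the same on the shorter chain of compound 3 also stays open.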